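From 3,4-dihydroxyphenyl to 3,4,5-trihydroxyphenyl in the series

The source may hold more compounds than are shown below. What is called first, only, known or untested is meant among the compounds shown, and "the series" means these compounds.

In a physicochemical assay, read by spectrophotometry, with a stated time of 6 min (on this read-out lower numbers stand for stronger inhibition and higher numbers for weaker inhibition), compound 1 `O=C(CCc1nc2ccccc2c(=O)[nH]1)N/N=C/c1ccc(O)c(O)c1` gives 40000000 nM and compound 2 `COc1cc(/C=N/NC(=O)CCCc2nc3ccccc3c(=O)[nH]2)cc(OC)c1OC` gives 60000000 nM. These two values lie within the scatter of each other, so compound 1 sits at the low end of the three numbers, level with compound 2. Compound 3 `O=C(CCCc1nc2ccccc2c(=O)[nH]1)N/N=C/c1ccc([N+](=O)[O-])cc1` gives 270000000 nM, a higher number than compound 1 by a margin beyond the scatter.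

Compound 4 `O=C(CCc1nc2ccccc2c(=O)[nH]1)N/N=C/c1cc(O)c(O)c(O)c1` differs from compound 1 by hydroxy in place of hydrogen on an aromatic carbon, ortho to a hydroxy group, meta to a hydroxy group and meta to a large group.

Within the data shown here, no measured pair isolates this change, so any forecast for it is loose. A modest step toward a lower number in this assay is expected, and it may not clear the scatter. The expected change is a 1.6-fold lower number from compound 1 to compound 4 (0.20 log units; within the scatter). For compound 4 the estimated value is 25000000 nM, with an expected range of 9000000 nM to 60000000 nM.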

Compound 4, half-maximal inhibitory concentration: 35000000 nM
Estimate against measurement, compound 4: 1.4-fold (0.15 log units) below, within the range that was stated.
By their numbers in this assay, from the lowest: compounds 4, 1 and 2 (each within the scatter of the next); then compound 3.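

In this assay, hydroxy in place of hydrogen on an aromatic carbon, ortho to a hydroxy group, meta to a hydroxy group and meta to a large group, gives a 1.1-fold lower number from compound 1 to compound 4 (0.06 log units; within the scatter). This is the only pair shown that differs in one place, and it shows that 3,4-dihydroxyphenyl and 3,4,5-trihydroxyphenyl cannot be told apart on this read-out, so the change leaves the number where compound 1 had it. Nothing measured here accounts for this outcome.

Going by these compounds, whether an amine or a carboxylic acid on the same aromatic carbon would move the number remains open. Compound 2 and compound 3 each differ from compound 1 in more than one place, so the effects of chain length and of the other aromatic groups cannot be separated.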